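Amine swap at the chain end of a quinazoline series

A few compounds are considered here, and "the series" means these few. Any claim that something is new, unique, unknown or untested is made for them only; others in the source may bear on it.

Compound 1 `COc1cc2c(Nc3ccc(C#N)cc3)ncnc2cc1OCCCN1CCCC1`: 14400 nM
Compound 2 `COc1cc2c(Nc3ccc(C#N)cc3)ncnc2cc1OCCCN1CCC(CO)CC1`: 53200 nM

In a functional assay on DU-145 cells (Homo sapiens) for antiproliferative activity, read by MTT assay, with a stated time of 72 h (on this read-out lower numbers stand for stronger inhibition and higher numbers for weaker inhibition), compound 2 gives 53200 nM, the higher of the two numbers measured; compound 1 gives 14400 nM. Going by the values given here, the one measured step, a 3.7-fold higher number from compound 1 to compound 2 (0.57 log units; beyond the scatter), shows the hydroxymethyl-piperidine costing potency against the pyrrolidine. Compound 3 `COc1cc2c(Nc3ccc(C#N)cc3)ncnc2cc1OCCCN1CCc2ccccc2C1` carries the change (1,2,3,4-tetrahydroisoquinolin-2-yl in place of 4-(hydroxymethyl)piperidin-1-yl on a saturated chain carbon, three bonds along the chain from an oxygen on an aromatic ring), which removes the hydrogen-bond donor that entered in that step. Among the compounds with values here, no measured step covers this exact exchange, so the expectation is only that compound 3 moves back toward compound 1, estimated as a 2.7-fold lower number from compound 2 to compound 3 (0.42 log units; beyond the scatter), giving 20000 nM with a range of 7000 nM to 60000 nM.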

Compound 3, half-maximal inhibitory concentration: > 100000 nM
Compound 3 gave a limit, no number; the forecaster's own chance of this, stated with the estimate: 10%; middle value at least 5.0-fold (0.69 log units) from the limit.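

In this assay compound 3 reaches only a limit of the assay, not a number: the limit of > 100000 nM in this assay, at which 1 of the 3 values shown sits. Taking out the hydroxymethyl did not bring the number back toward the pyrrolidine: the result is an at least 1.8-fold higher number from compound 2 to compound 3 (0.27 log units; that floor lies within the scatter), and an at least 6.9-fold higher number from compound 1 to compound 3 (0.84 log units; beyond the scatter). Both replacements of pyrrolidin-1-yl at this chain end therefore give higher numbers, with or without a hydrogen-bond donor. From the compounds shown here alone, how far compound 3 really lies from compound 2 stays open. So does whether an unsubstituted piperidine or a morpholine would stay close to compound 1.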